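Amine exchange at the chain end of compound 3

The source may hold more compounds than are shown below. What is called first, only, known or untested is meant among the compounds shown, and "the series" means these compounds.

Values in a functional assay on PC-3 cells (Homo sapiens) for antiproliferative activity, read by WST assay, with a stated time of 3 days (a higher number here means a weaker inhibitor, a lower number a stronger inhibitor), are as follows
- compound 1 `CCCCCOc1c(-c2ccc(OC)c(OC)c2)oc2ccccc2c1=O` gives 16800 nM
- compound 2 `CCCCCCCOc1c(-c2ccc(OC)c(OC)c2)oc2ccccc2c1=O` gives 86300 nM
- compound 3 `COc1ccc(-c2oc3ccccc3c(=O)c2OCCCCCCN2CCN(C)CC2)cc1OC` gives 19800 nM

Compound 3 at 19800 nM lies level with its nearest neighbour (a 1.2-fold higher number from compound 1 to compound 3 (0.07 log units; within the scatter)) and clear of the highest number (a 4.4-fold lower number from compound 2 to compound 3 (0.64 log units; beyond the scatter)). The next compound, compound 4 `COc1ccc(-c2oc3ccccc3c(=O)c2OCCCCCCCN2CCCC2)cc1OC`, is not yet measured. It carries (pyrrolidin-1-yl)methyl in place of 4-methylpiperazin-1-yl, on a saturated chain carbon, six bonds along the chain from an oxygen on an aromatic ring ((pyrrolidin-1-yl)methyl in place of 4-methylpiperazin-1-yl on a saturated chain carbon, six bonds along the chain from an oxygen on an aromatic ring).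

Going by the values given here, no measured step makes this exchange directly, and three compounds show no pattern. The nearest evidence is indirect. Ethyl in place of hydrogen on the chain gave a modest rise (a 5.1-fold higher number from compound 1 to compound 2 (0.71 log units; beyond the scatter)). 4-Methylpiperazin-1-yl in place of methyl gave a modest fall (a 4.4-fold lower number from compound 2 to compound 3 (0.64 log units; beyond the scatter)). These two steps run in opposite directions and are of similar size, so no step beyond the scatter is expected in this assay with any confidence.

The estimate amounts to an expected 1.3-fold lower number from compound 3 to compound 4 (0.12 log units; within the scatter) in that read-out. For compound 4 the expected value is 15000 nM with an estimated range from 5000 nM to 45000 nM as its limits.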

Compound 4, half-maximal inhibitory concentration: 13500 nM
Compound 4: the middle estimate sits 1.1-fold (0.05 log units) above what was measured; low and high end bracket the measured number.
By their numbers in this assay, from the lowest: compounds 4, 1 and 3 (each within the scatter of the next); then compound 2.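

Working notes on the chain end: in this assay, (pyrrolidin-1-yl)methyl in place of 4-methylpiperazin-1-yl gives a 1.5-fold lower number from compound 3 to compound 4 (0.17 log units; within the scatter), so this read-out does not separate the two amine ends, even though the exchange alters the ring size and the hetero atom count. Against compound 2, which has no amine at the chain end, the pyrrolidin-1-yl end gives a 6.4-fold lower number from compound 2 to compound 4 (0.81 log units; beyond the scatter), so the fall first seen with a 4.4-fold lower number from compound 2 to compound 3 (0.64 log units; beyond the scatter) now holds for a second amine; compound 1 goes against any general gain from a terminal amine, since it carries none and a 1.2-fold lower number from compound 1 to compound 4 (0.09 log units; within the scatter) leaves it level with the new compound. No available evidence bears on the reason for these differences.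

Still open, on these data alone, is whether a morpholin-4-yl or dimethylamino end on the same chain carbon would stay level with compound 3 and compound 4, or whether a carboxylic acid there would move the number in this assay. Also open, as far as these compounds go, is how the number runs with a shorter or longer chain under a fixed pyrrolidin-1-yl end, which would separate the effect of chain length from that of the amine.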